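The source may report more compounds than this note shows. Statements on the series, on what has been measured and on what is new or still open speak of the compounds shown alone.

Working notes on the sulfonamide series. The shared core, seen in compound 1 `COc1ccc(CNCCCNS(=O)(=O)c2cc(C(F)(F)F)cc(C(F)(F)F)c2)cc1OC`, carries a 3,4-dimethoxybenzyl group on the amine nitrogen; in a functional assay on HT-29 cells (Homo sapiens) for inhibition, read by MTT assay, with a stated time of 72 h (a lower number here means a stronger inhibitor of growth, a higher number a weaker inhibitor of growth), compound 1 gives 2700 nM. Compound 2 `O=S(=O)(NCCCNCc1ccccc1)c1cc(C(F)(F)F)cc(C(F)(F)F)c1` keeps everything except that benzyl group, and in this assay compound 2 gives 15000 nM. Among the compounds with values here, the single step between them, a 5.6-fold higher number from compound 1 to compound 2 (0.74 log units; beyond the scatter), is the only comparison available, and it puts compound 2 at the highest of the two numbers, with compound 1 the only neighbour.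

Compound 3 `O=S(=O)(NCCCNCc1ccc(Br)cc1)c1cc(C(F)(F)F)cc(C(F)(F)F)c1` is next, differing from compound 2 by bromo in place of hydrogen on an aromatic carbon. Within the data shown here, no measured step bears directly on a halogen on this ring; the one step in hand concerns loss of the two methoxy groups, and says nothing about a bromo entering. A weaker-than-scatter to modest downward step in this assay is expected for the move from compound 2 to compound 3, a 1.9-fold lower number from compound 2 to compound 3 (0.27 log units; within the scatter), so compound 3 is estimated at 8000 nM, within 2500 nM to 25000 nM.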

Compound 3, concentration for 50% growth inhibition: 2200 nM
Compound 3: the middle estimate sits 3.6-fold (0.56 log units) above what was measured, and the stated range ends above it.
By their numbers in this assay, from the lowest: compounds 3 and 1 (each within the scatter of the next); then compound 2.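

Moving from the unsubstituted benzyl group to 4-bromobenzyl gives a 6.8-fold lower number from compound 2 to compound 3 (0.83 log units; beyond the scatter) in this assay, so a single bromo on this ring is enough to separate a compound from compound 2. Against the 3,4-dimethoxybenzyl group, the change gives a 1.2-fold lower number from compound 1 to compound 3 (0.09 log units; within the scatter), which leaves the one bromo and the two methoxy groups indistinguishable in this read-out, and both substituted compounds give lower numbers than compound 2. No measurement here accounts for this effect of ring substitution.

The compounds shown leave open whether bromine itself matters or whether chloro, methyl or a single methoxy group at the same place would give a similar number. On these data alone, it also remains open whether the step from hydrogen to bromo would hold with a longer chain in the shared core.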